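A few compounds are considered here, and "the series" means these few. Any claim that something is new, unique, unknown or untested is made for them only; others in the source may bear on it.

Compound 2 `Cc1cc(-c2c(C)nn(C)c2C)cnc1-c1nnc(N(C)Cc2ccc3ncc(-c4cnn(CCN(C)C)c4)n3c2)o1` stands lowest of the two numbers in a physicochemical assay for lipophilicity, at pH 7.4; on this read-out higher numbers stand for higher lipophilicity and lower numbers for lower lipophilicity; compound 1 `Cc1cc(-c2c(C)nn(C)c2C)cnc1-c1nnc(N(C)Cc2ccc3nccn3c2)o1` gives 2.8 and compound 2 gives 2.7, so the two are within the scatter. Compound 3 `Cc1cc(-c2c(C)nn(C)c2C)cnc1-c1nnc(N(C)Cc2ccc3ncc(-c4cccc(CN(C)C)c4)n3c2)o1` differs from compound 2 by 3-((dimethylamino)methyl)phenyl in place of 1-(2-(dimethylamino)ethyl)-1H-pyrazol-4-yl on an aromatic carbon. Within the data shown here, the only measured step, a number 0.10 log units lower from compound 1 to compound 2 (within the scatter), adds the group that now leaves and is within the scatter; no measured step covers the group that enters. The expected step of a number 0.40 log units higher from compound 2 to compound 3 (beyond the scatter) is therefore small and uncertain. Compound 3 is estimated at 3.1 in this assay, within 2.5 to 3.7.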

Compound 3, distribution coefficient: 3
Estimate against measurement, compound 3: 0.10 log units above, within the range that was stated.
By their numbers in this assay, from the lowest: compounds 2, 1 and 3 (each within the scatter of the next).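

Two different groups on this aromatic carbon now sit close to hydrogen in this assay: 3-((dimethylamino)methyl)phenyl gives a number 0.20 log units higher from compound 1 to compound 3 (within the scatter) and replacing 1-(2-(dimethylamino)ethyl)-1H-pyrazol-4-yl with it gives a number 0.30 log units higher from compound 2 to compound 3 (within the scatter). Exchanging the five-membered aromatic ring with 2 hetero atoms for a six-membered aromatic ring of carbon only therefore leaves the read-out within the scatter for this pair. No supporting data bear on why these values lie so close.

Open, on these data alone, is whether a plain phenyl or a carboxylic acid at this place would also stay this close. As far as these compounds go, a longer chain to the dimethylamino group is equally open.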